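Methyl on the sulfonyl ring: from compound 2 to compound 3

The source may report more compounds than this note shows. Statements on the series, on what has been measured and on what is new or still open speak of the compounds shown alone.

Measured compounds:
compound 1, `Cc1ccc(S(=O)(=O)NC(=O)/C=C/c2ccc(Br)cc2)cc1`, 12.1 ug/mL
compound 2, `COc1ccc(/C=C/C(=O)NS(=O)(=O)c2ccccc2)cc1`, 13.2 ug/mL

In a functional assay on B16-F10 cells (Mus musculus) for antiproliferative activity, read by ELISA and MTT assay, with a stated time of 48 h (a higher number here means a weaker inhibitor, a lower number a stronger inhibitor), compound 1 gives 12.1 ug/mL. In this assay compound 2 gives 13.2 ug/mL. Compound 2 stands alongside compound 1, the two numbers lying within the scatter of each other, so the data show no separation between them.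

Compound 3, `COc1ccc(/C=C/C(=O)NS(=O)(=O)c2ccc(C)cc2)cc1`, is not yet measured. It differs from compound 2 by methyl in place of hydrogen on an aromatic carbon. Going by the values given here, the change adds one carbon and nothing else; compound 1 carries the same 4-methylphenyl on its sulfonyl and sits within the scatter of compound 2, which is the only guide available.

The step is therefore expected to be small: a 1.1-fold lower number from compound 2 to compound 3 (0.04 log units; within the scatter) is estimated to lie within the scatter, in no clear direction. Compound 3 is expected to give about 12 ug/mL, within a range of 6 ug/mL to 24 ug/mL.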

Compound 3, half-maximal inhibitory concentration: 12.2 ug/mL
For compound 3 the middle estimate is 1.0-fold (0.01 log units) below the measured one; measured number inside the range.
By their numbers in this assay, from the lowest: compounds 1, 3 and 2 (each within the scatter of the next).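

In this assay, methyl in place of hydrogen on an aromatic carbon of the sulfonyl ring, phenyl to 4-methylphenyl, gives a 1.1-fold lower number from compound 2 to compound 3 (0.03 log units; within the scatter) and thus no separation in this first direct test of the change. With the 4-methylphenyl held constant, methoxy in place of bromo on an aromatic carbon gives a 1.0-fold higher number from compound 1 to compound 3 (0.00 log units; within the scatter) and so also shows no separation for this single exchange. No measured evidence bears on these results.

What the compounds leave open is whether an amine, a carboxylic acid or a longer chain such as propyl in place of the methyl would stand apart from compound 3 in this assay. They also leave open whether methoxy and bromo would stand equally close on the phenyl form of the sulfonyl ring, or whether a hydroxyl at that aromatic carbon would do so.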